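The source may report more compounds than this note shows. Statements on the series, on what has been measured and on what is new or still open speak of the compounds shown alone.

Measured compounds:
compound 1, `CC(C)c1cccc(NC(=O)N[C@H](C)c2ccccc2)c1` — 61%
compound 2, `CC(C)c1cccc(NC(=O)N[C@@H](C)c2ccccc2)c1` — 84%
compound 3, `C[C@H](NC(=O)Nc1ccccc1F)c1ccccc1` — 92%

In an ADME assay on the whole organism with Oryza sativa as the target, tested at 1 uM (on this read-out higher numbers stand for a weaker effect at the one concentration tested and lower numbers for a stronger effect), compound 1 gives the lowest of the three numbers, the strongest effect among them. Compound 2 stands nearest to it, and the step of a number 23 percentage points higher from compound 1 to compound 2 (beyond the scatter) lies beyond the scatter; compound 3 stands furthest away. The step from compound 1 to compound 2 arises because of the fact that compounds 1 and 2 differ only in the configuration as drawn and says nothing about substitution on the aromatic ring.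

Compound 4, `C[C@@H](NC(=O)Nc1cccc(Cl)c1)c1ccccc1`, has not yet been measured. The change from compound 1 is chloro in place of isopropyl on an aromatic carbon. Among the compounds with values here, no measured step among compounds 1 to 3 covers this kind of exchange, so nothing in the data fixes its size or direction. Given that both other measured compounds sit higher than compound 1, a modest rise toward them is expected rather than a further fall. Compound 4 is therefore estimated at 75%, between 52% and 95%, which would mean an expected step of a number 14 percentage points higher from compound 1 to compound 4 (beyond the scatter).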

Compound 4, a percentage reported as activity, at one concentration (the size of the read-out at that concentration, not a potency): 91%
Estimate against measurement, compound 4: 16 percentage points below, within the range that was stated.
By their numbers in this assay, from the lowest: compound 1; then compounds 2, 4 and 3 (each within the scatter of the next).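

In this assay, chloro in place of isopropyl on an aromatic carbon, meta to a large group, gives a number 30 percentage points higher from compound 1 to compound 4 (beyond the scatter). Within the data shown here, this is the first sign that the group at this place on the ring moves the read-out, as the earlier step could speak only to configuration; here the higher number means a weaker effect at the one concentration tested, with chloro compared with isopropyl. Nothing at hand gives a cause for this step.

The compounds shown leave open whether a smaller or a larger group at this place, such as methyl or tert-butyl, would fall nearer to isopropyl or to chloro. They also leave open how a polar group such as an amine or a carboxylic acid would read there, and whether configuration matters as much in the chloro series.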